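A few compounds are considered here, and "the series" means these few. Any claim that something is new, unique, unknown or untested is made for them only; others in the source may bear on it.

Values in a functional assay on HeLa cells (Homo sapiens) for antiproliferative activity, read by MTT assay, with a stated time of 48 h; a lower number here means a stronger inhibitor, a higher number a weaker inhibitor:

Compound 1 `Cn1c(N)c(-c2nc3ccccc3[nH]2)c2nc(C#N)c(C#N)nc21`: > 50000 nM, a limit
Compound 2 `CN(C)CCn1c(N)c(-c2nc3ccccc3[nH]2)c2nc(C#N)c(C#N)nc21`: 8880 nM
Compound 3 `CN(C)CCn1c(N)c(-c2nc3ccccc3n2C)c2nc(C#N)c(C#N)nc21`: > 50000 nM, a limit

Compound 3 has no number, only a limit, and it stands with the limit of > 50000 nM in this assay, at which 2 of the 3 values shown sit. Compound 4 `CN(C)CCCCn1c(N)c(-c2nc3ccccc3n2C)c2nc(C#N)c(C#N)nc21` keeps the methyl on the aromatic nitrogen and changes the chain: 2-(dimethylamino)ethyl in place of dimethylamino on a saturated chain carbon, two bonds along the chain from an aromatic nitrogen. This places 2-(dimethylamino)ethyl in place of dimethylamino on a saturated chain carbon, two bonds along the chain from an aromatic nitrogen.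

For the measured compounds named here, two measured steps bear on this change. The first, an at least 5.6-fold lower number from compound 1 to compound 2 (0.75 log units; beyond the scatter), came with (dimethylamino)methyl in place of hydrogen on that chain, so changes there can register in this assay. The second, an at least 5.6-fold higher number from compound 2 to compound 3 (0.75 log units; beyond the scatter), came with methyl in place of hydrogen on an aromatic nitrogen, and compound 4 retains that methyl. Neither step varies chain length, so only a modest move towards a lower number is expected, and a reading at the limit remains quite possible. The expected step is an at least 1.6-fold lower number from compound 3 to compound 4 (0.22 log units; that floor lies within the scatter). For compound 4 the estimated value is 30000 nM, with an expected range of 10000 nM to 50000 nM.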

Compound 4, half-maximal inhibitory concentration: 460 nM
Compound 4: the middle estimate sits 65-fold (1.81 log units) above what was measured; measured number below the stated range.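

In this assay, for the compounds shown here, 2-(dimethylamino)ethyl in place of dimethylamino on a saturated chain carbon, two bonds along the chain from an aromatic nitrogen, gives an at least 100-fold lower number from compound 3 to compound 4 (2.03 log units; beyond the scatter), so chain length at this position registers strongly, which no earlier pair could show. The methyl on the aromatic nitrogen, which came with an at least 5.6-fold higher number from compound 2 to compound 3 (0.75 log units; beyond the scatter), does not rule out a low reading, as compound 4 retains it. The full size of the new step stays open because compound 3 carries only a limit and no number: the limit of > 50000 nM in this assay, at which 2 of the 4 values shown sit.

Still open, from the compounds shown here alone, is whether the intermediate 3-(dimethylamino)propyl chain or a chain longer than 4-(dimethylamino)butyl would read lower or higher. Also open, going by these compounds, are the effect of hydrogen in place of the methyl on the aromatic nitrogen with the chain of compound 4, and of a morpholine in place of the terminal dimethylamino.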